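The compounds below may be only part of what the source reports. "The series", "measured", "known", "first", "only" and "open" are said of these compounds alone.

Measured to date in a physicochemical assay for solubility, at pH 2; on this read-out lower numbers stand for lower solubility and higher numbers for higher solubility:
compound 1 `CS(=O)(=O)c1cncc(-c2ccc3ncc(-c4cncc(S(C)(=O)=O)c4)n3n2)c1`: 183000 nM
compound 2 `CS(=O)(=O)c1ccc(-c2cnc3ccc(-c4cccc(C(=O)NCCO)c4)nn23)cc1`: > 200000 nM
compound 3 `O=S(=O)(c1cccc(-c2ccc3ncc(-c4ccc(-c5nnn[nH]5)cc4)n3n2)c1)C1CC1`: < 5000 nM

Compound 2 has no plain number in this assay, only (the limit of > 200000 nM in this assay, at which 1 of the 3 values shown sits), which is a limit of the assay. Compound 3 likewise sits at the limit of < 5000 nM in this assay, at which 1 of the 3 values shown sits, also a limit. Only compound 1 carries a measured number, 183000 nM. Within the data shown here, no pair of measured compounds differs in a single place, so nothing measured frames the change to compound 4 `C[S+]([O-])c1cccc(-c2ccc3ncc(-c4ccc(S(C)(=O)=O)cc4)n3n2)c1`. Relative to compound 2, compound 4 carries a group of 3 heavy atoms (1 carbon, 1 oxygen, 1 sulfur; no ring) in place of a group of 6 heavy atoms (3 carbon, 1 nitrogen, 2 oxygen; no ring), on an aromatic carbon. With compound 2 known only as a limit, the size of the step cannot be anchored from the data; a move downward beyond the usual scatter is expected rather than none. For compound 4 in this assay an estimated 60000 nM is expected, within 15000 nM to 200000 nM. The expected step is an at least 3.3-fold lower number from compound 2 to compound 4 (0.52 log units; beyond the scatter), pointing to lower solubility.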

Compound 4, solubility: 188000 nM
Beside the measured number, compound 4's estimate is 3.1-fold (0.50 log units) below it, within the range that was stated.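

In this assay, among these compounds, replacing (2-hydroxyethyl)carbamoyl on this aromatic carbon with the group of compound 4 gives a first readable step at this position: an at least 1.0-fold lower number from compound 2 to compound 4 (0.02 log units; that floor lies within the scatter). Compound 2 stands at a limit of the assay, so this step is only a floor and its true size stays unread: the limit of > 200000 nM in this assay, at which 1 of the 4 values shown sits.

Without the (2-hydroxyethyl)carbamoyl group, compound 4 still gives 188000 nM.

Open, as far as these compounds go, is how a carboxylic acid or an amine on this aromatic carbon would read in this assay on the shared core.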